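From 4-isopropylphenyl to 3-fluorophenyl on the amide nitrogen

The source may report more compounds than this note shows. Statements on the series, on what has been measured and on what is new or still open speak of the compounds shown alone.

For the measured compounds named here, in a functional assay on HepG2 cells (Homo sapiens) for inhibition, read by MTT assay, with a stated time of 72 h (on this read-out higher numbers stand for weaker inhibition and lower numbers for stronger inhibition), compound 1 `CC(C)c1ccc(NC(=O)C2CCN(C/C=C/c3ccccc3)CC2)cc1` gives 12200 nM, the higher of the two numbers measured so far and so the weaker inhibition. Its relative, compound 2 `CCCCCc1ccc(NC(=O)C2CCN(C/C=C/c3ccccc3)CC2)cc1`, gives 2890 nM. Compound 3 `O=C(Nc1cccc(F)c1)C1CCN(C/C=C/c2ccccc2)CC1` has not yet been measured. It differs from compound 1 on an amide-type nitrogen, where 3-fluorophenyl stands in place of 4-isopropylphenyl: 3-fluorophenyl in place of 4-isopropylphenyl on an amide-type nitrogen.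

Going by the values given here, only one measured step bears on this change. It is a 4.2-fold lower number from compound 1 to compound 2 (0.63 log units; beyond the scatter), a modest step beyond the scatter, with pentyl in place of isopropyl on an aromatic carbon. Among the compounds with values here, compound 3 carries neither of those groups, and no measured compound carries a fluorine, so this step is only a loose guide. The lower number came with pentyl, so in this assay a small shift towards a higher number is expected, not a gain. The estimate is a 1.3-fold higher number from compound 1 to compound 3 (0.12 log units; within the scatter), a step expected to stay within the usual scatter. For compound 3 the expected value is 16000 nM, with an estimated range from 6000 nM to 40000 nM.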

Compound 3, half-maximal inhibitory concentration: 51100 nM
Compound 3: middle estimate off by 3.2-fold (0.50 log units), on the low side; measured number outside the range, above it.
By their numbers in this assay, from the lowest: compound 2; then compound 1; then compound 3.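

In this assay, the group on the amide-type nitrogen can move the number in either direction: with the rest of the core of compound 1 unchanged, 3-fluorophenyl in place of 4-isopropylphenyl gives a 4.2-fold higher number from compound 1 to compound 3 (0.62 log units; beyond the scatter), which means weaker inhibition by a step beyond the scatter. For the compounds shown here, the earlier compounds showed only a gain, a 4.2-fold lower number from compound 1 to compound 2 (0.63 log units; beyond the scatter), when pentyl replaced isopropyl, so this is the first sign that a change to this aromatic group can also cost inhibition. The data shown offer no measurement that explains the loss.

This single step replaces isopropyl with fluorine and also changes where the group sits on the aromatic ring, so the effects of the two changes cannot be told apart. A 4-fluorophenyl or 3-isopropylphenyl group would separate them, while a plain phenyl group would show how the number stands with neither isopropyl nor fluorine on the ring.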